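Swapping nitro for fluoro at the limit of the assay

This account rests on a few compounds, and the source may have more. Where it says the series, first, only, none or still open, it means among the compounds named here.

Compound 1 `O=C1/C(=C/c2ccncc2)CN(S(=O)(=O)c2ccc(F)cc2)C/C1=C\c1ccccc1F`: > 20000 nM (a limit)
Compound 2 `O=C1/C(=C/c2ccncc2)CN(S(=O)(=O)c2ccc([N+](=O)[O-])cc2)C/C1=C\c1ccccc1C(F)(F)F`: > 20000 nM (a limit)

In a functional assay on SMMC-7721 cells (Homo sapiens) for cytotoxicity, read by MTT assay, with a stated time of 24 h (on this read-out higher numbers stand for weaker inhibition and lower numbers for stronger inhibition), compound 2 stands at > 20000 nM, which is a limit and not a number. Compound 3 `O=C1/C(=C/c2ccncc2)CN(S(=O)(=O)c2ccc(F)cc2)C/C1=C\c1ccccc1C(F)(F)F` differs from compound 2 by having fluoro in place of nitro on an aromatic carbon, para to a large group: fluoro in place of nitro on an aromatic carbon. No step beyond the usual scatter is expected in this assay because compound 1 with its (4-fluorophenyl)sulfonyl shows the limit > 20000 nM. The estimated change is a number no higher from compound 2 to compound 3 (the limit leaves the size open). For compound 3 the expected value is 20000 nM, with an estimated range from 8000 nM to 40000 nM.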

Compound 3, half-maximal inhibitory concentration: 9270 nM
Beside the measured number, compound 3's estimate is 2.2-fold (0.33 log units) above it; low and high end bracket the measured number.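

In this assay fluoro in place of nitro on an aromatic carbon gives an at least 2.1-fold lower number from compound 2 to compound 3 (0.33 log units; beyond the scatter) and shows that this position can move the read-out. Trifluoromethyl in place of fluoro on an aromatic carbon gives an at least 2.1-fold lower number from compound 1 to compound 3 (0.33 log units; beyond the scatter) and shows that, among these compounds, a measurable number appears only where (4-fluorophenyl)sulfonyl and trifluoromethyl occur together. The full size of both steps stays unknown because each starts from a limit: the limit of > 20000 nM in this assay, at which 2 of the 3 values shown sit.

Going by these compounds, whether an amine or a methoxy group in place of fluoro at this position would lower the number further remains open.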